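Iodo in Place of Furan-3-yl on a Shared Core

The compounds below may be only part of what the source reports. "The series", "measured", "known", "first", "only" and "open" are said of these compounds alone.

Compound 3 `CNc1ncnc2c1c(-c1ccoc1)cn2[C@@H]1O[C@H](CO)[C@@H](O)[C@H]1O` was tested in a functional assay on A549 cells (Homo sapiens), read by MTT assay, with a stated time of 72 h; a higher number here means a weaker inhibitor, a lower number a stronger inhibitor. In this assay compound 3 gives > 20000 nM, which is a limit of the assay rather than a number. Compound 2 `CNc1ncnc2c1c(-c1cccs1)cn2[C@@H]1O[C@H](CO)[C@@H](O)[C@H]1O` likewise gives > 20000 nM, again a limit. Compound 1 `COc1ncnc2c1c(I)cn2[C@@H]1O[C@H](CO)[C@@H](O)[C@H]1O` gives > 20000 nM, also a limit. The step that the two limits leave unreadable from compound 2 to compound 3 therefore cannot be read. Compound 4 `CNc1ncnc2c1c(I)cn2[C@@H]1O[C@H](CO)[C@@H](O)[C@H]1O` differs from compound 3 by iodo in place of furan-3-yl on an aromatic carbon. Among the measured compounds shown here, no measured step bears on this change, because the limit of > 20000 nM in this assay, at which 3 of the 3 values shown sit, leaves every comparison unreadable. With nothing to lean on, no shift beyond the scatter is expected, and the step of a number no higher from compound 3 to compound 4 (the limit leaves the size open) is only an estimate. Compound 4 is expected to give about 20000 nM, between 8000 nM and 50000 nM, most likely reported once more as a limit.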

Compound 4, half-maximal inhibitory concentration: > 100000 nM
Compound 4: only a limit was reported (the forecaster's own chance of this, stated with the estimate: 80%); middle value at least 5.0-fold (0.69 log units) from the limit.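

Among the compounds shown here, no step from compound 1, compound 2 or compound 3 to compound 4 can be read, since all four values in this assay are limits. The compounds shown leave open how strongly any of them inhibits.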